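Methyl in place of methylamino: working notes

This account rests on a few compounds, and the source may have more. Where it says the series, first, only, none or still open, it means among the compounds named here.

Compound 1 `CSc1ncnc2c1c(-c1cccs1)cn2[C@@H]1O[C@H](CO)[C@@H](O)[C@H]1O` gives 1960 nM as a number
Compound 2 `CNc1ncnc2c1c(-c1cccs1)cn2[C@@H]1O[C@H](CO)[C@@H](O)[C@H]1O` gives > 20000 nM as a limit
Compound 3 `CNc1ncnc2c1c(-c1ccccc1)cn2[C@@H]1O[C@H](CO)[C@@H](O)[C@H]1O` gives > 20000 nM as a limit

Compound 2 stands at > 20000 nM in a functional assay on HeLa S3 cells (Homo sapiens) for antiproliferative activity, read by XTT assay, with a stated time of 72 h (a higher number here means a weaker inhibitor, a lower number a stronger inhibitor), and that is a limit, not a number. Compound 4 `Cc1ncnc2c1c(-c1cccs1)cn2[C@@H]1O[C@H](CO)[C@@H](O)[C@H]1O` is the next case, with methyl in place of methylamino on an aromatic carbon in the change of methyl in place of methylamino on an aromatic carbon. Among the compounds with values here, no measured compound here carries methyl at that place. The closest measured step is an at least 10-fold higher number from compound 1 to compound 2 (1.00 log units; beyond the scatter) in the same place, with thiophen-2-yl kept. The other step, a step that the two limits leave unreadable from compound 2 to compound 3 at a different place, gives no size to work with. Both compounds with methylamino sit at the limit. The expectation therefore leans on compound 1 at 1960 nM in the absence of methylamino. The expected change is an at least 13-fold lower number from compound 2 to compound 4 (1.12 log units; beyond the scatter) towards a lower number, though a reading at the limit remains possible. In this assay the estimated value for compound 4 is 1500 nM with an expected range from 200 nM to 15000 nM for this compound.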

Compound 4, half-maximal inhibitory concentration: > 15000 nM
Compound 4 was reported as a limit; the forecaster's own chance of this, stated with the estimate: 20%; at least 10-fold (1.00 log units) between middle value and limit.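

In this assay, methyl in place of methylsulfanyl gives an at least 7.6-fold higher number from compound 1 to compound 4 (0.88 log units; beyond the scatter), so the loss at this place is not tied to methylamino and appears with methyl as well. Within the data shown here, with thiophen-2-yl kept, compound 1 at 1960 nM is the only one of the three compounds with a number, which singles out methylsulfanyl among the groups tried at this place. Compound 4 carries a limit and not a number, and the step between methylamino and methyl cannot be read: the limit of > 15000 nM in this assay, at which 1 of the 4 values shown sits.

As far as these compounds go, whether the gain belongs to the sulfur link or to the methylsulfanyl group as a whole stays open, and an ethylsulfanyl chain or a methoxy group at this place would bear on it. Also open, from the compounds shown here alone, is whether methylsulfanyl keeps its number with phenyl in place of thiophen-2-yl.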